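This account rests on a few compounds, and the source may have more. Where it says the series, first, only, none or still open, it means among the compounds named here.

Measured so far:
compound 1, `COc1cccc(Cc2cc(C(C)C)nn(CC(=O)Nc3ccc(Br)cc3)c2=O)c1`: > 50000 nM
compound 2, `COc1cccc(Cc2cc(-c3ccccc3)nn(CC(=O)Nc3ccc(F)cc3)c2=O)c1`: > 50000 nM
compound 3, `COc1ccc(Cc2cc(-c3ccc(OC)cc3)nn(CC(=O)Nc3ccc(Br)cc3)c2=O)cc1`: > 50000 nM

All three compounds were tested in a functional assay on HL-60 cells (Homo sapiens), read by calcium flux; on this read-out higher numbers stand for an effect only at larger amounts of compound and lower numbers for an effect already at smaller amounts. For compound 3 the result is not a number but a limit, > 50000 nM, meaning no effect was seen up to the highest amount tested. The same holds for compound 1 with its limit of > 50000 nM. Compound 2 likewise gives only a limit, > 50000 nM. Within the data shown here, this is the ceiling of this assay, at which every value so far sits (the limit of > 50000 nM in this assay, at which 3 of the 3 values shown sit). Among the measured compounds shown here, compound 3 therefore stands nowhere above or below the others: it shares the limit with them, and no step between any two measured compounds can be sized.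

Compound 4, `COc1ccc(Cc2cc(-c3ccc(F)cc3)nn(CC(=O)Nc3ccc(Br)cc3)c2=O)cc1`, has not yet been measured. It differs from compound 3 in one place: fluoro in place of methoxy on an aromatic carbon. With no measured step to lean on and every shown value at the limit, no change beyond the scatter of this assay is expected, and the step from compound 3 to compound 4 is estimated as a number no higher from compound 3 to compound 4 (the limit leaves the size open). Compound 4 is expected to give 50000 nM in this assay, within 15000 nM to 50000 nM, most likely again as a limit rather than a number.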

Compound 4, half-maximal effective concentration: > 50000 nM
Compound 4: only a limit was reported; the forecaster's own chance of this, stated with the estimate: 80%; the middle value sits exactly at the limit.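

No step can be read from compound 3 to compound 4 in this assay, because both results are limits and not numbers: the limit of > 50000 nM in this assay, at which 4 of the 4 values shown sit.

The compounds shown leave open what, if anything, would give a measurable effect in this assay, and how far 4-methoxyphenyl and 4-fluorophenyl truly differ there.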